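The compounds below may be only part of what the source reports. "The series", "measured", "known", "first", "only" and "open" are said of these compounds alone.

In a physicochemical assay for metabolic stability, read by LC-MS, in simulated gastric fluid, with a stated time of 15 min, tested at 50 uM (on this read-out lower numbers stand for a less stable compound and higher numbers for a more stable compound), two compounds have been examined so far. Compound 1 `O=C(OCc1ccccc1)[C@@H]1COC(c2ccccc2)=N1` gives 1.7% in this assay. Compound 2 `CCC(=O)c1ccccc1OC(=O)c1coc(-c2ccccc2)n1` gives 1.8% in this assay; it holds the higher of the two numbers, with compound 1 lying within the scatter of it, so the two results are indistinguishable and neither compound can be called the more stable.

The account now turns to compound 3 `O=C(Oc1ccccc1)c1coc(-c2ccccc2)n1`, which has not yet been measured in this assay. Relative to compound 2 the change is hydrogen in place of propanoyl on an aromatic carbon. For the measured compounds named here, no measured pair separates this change, so no reference step is available. Since both measured compounds sit at the low end of the scale, the step from compound 2 to compound 3 is expected to stay within the scatter, with a number 1.2 percentage points higher from compound 2 to compound 3 (within the scatter). Compound 3 is accordingly estimated at 3% in this assay, within a range of 0.5% to 15%.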

Compound 3, percent of the compound remaining: 0.2%
Estimate against measurement, compound 3: 2.8 percentage points above, outside the stated range (below it).
By their numbers in this assay, from the lowest: compounds 3, 1 and 2 (each within the scatter of the next).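

In this assay, hydrogen in place of propanoyl on an aromatic carbon, ortho to a large group, gives a number 1.6 percentage points lower from compound 2 to compound 3 (within the scatter). For the compounds shown here, this is the first step that can be read at this position, and it shows that the propanoyl and the hydrogen cannot be told apart on this read-out, with both compounds remaining at the low end of the scale. Nothing in the data at hand speaks to the reason for this result.

The compounds shown leave open whether any group on this aromatic carbon can move the number beyond the scatter, as an amine, a carboxylic acid or a longer chain there might or might not. They also leave open whether an amide in place of the ester linkage would change the number in this assay.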